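A longer side chain on compound 1

The source may hold more compounds than are shown below. What is called first, only, known or untested is meant among the compounds shown, and "the series" means these compounds.

Among the measured compounds shown here, in a functional assay on the whole organism (Tail, strain ICR) with Mus musculus as the target, in the tail flick test, with a stated time of 30 min, at a dose of 25 umol/kg by the oral route (on this read-out lower numbers stand for a weaker effect and higher numbers for a stronger effect at the one dose given), compound 1 `O=C(CN(c1ncnc2c1ncn2C1CCCCO1)C1CC1)NCC(=O)OCc1ccccc1` gives 55.7%, the highest of the three numbers known. Compound 3 `CC[C@H](C)[C@H](NC(=O)CN(c1nc(Cl)nc2[nH]cnc12)C1CC1)C(=O)OCc1ccccc1` gives 41.4%, a number beyond the scatter below compound 1, and compound 2 `C[C@@H](O)[C@H](NC(=O)CN(c1nc(Cl)nc2[nH]cnc12)C1CC1)C(=O)O` gives 18.6%, the furthest from compound 1 and also beyond the scatter. No two of these measured compounds differ in only one place, so no single step can be read from them. Compound 4 `CC(C)(C)OC(=O)NCCCC[C@H](NC(=O)CN(c1ncnc2c1ncn2C1CCCCO1)C1CC1)C(=O)OCc1ccccc1` has not yet been measured; it differs from compound 1 by 4-((tert-butoxycarbonyl)amino)butyl in place of hydrogen on a saturated chain carbon bound to an amide-type nitrogen and a carbonyl carbon. For the measured compounds named here, with no measured step to lean on, the author expects a modest weakening in this assay for the step of a number 10.7 percentage points lower from compound 1 to compound 4 (beyond the scatter), not a large one. Compound 4 is thus estimated to give 45%, with a range from 25% to 65%.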

Compound 4, a percentage reported as activity, at one dose (the size of the read-out at that dose, not a potency): 18.3%
Compound 4: the middle estimate sits 26.7 percentage points above what was measured; measured number outside the range, below it.
By their numbers in this assay, from the lowest: compounds 4 and 2 (each within the scatter of the next); then compound 3; then compound 1.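

In this assay, the saturated chain carbon bound to an amide-type nitrogen and a carbonyl carbon proves sensitive to substitution: 4-((tert-butoxycarbonyl)amino)butyl in place of hydrogen gives a large loss, a number 37.4 percentage points lower from compound 1 to compound 4 (beyond the scatter). Among the compounds shown here, this is the only single-place step in the set, so it shows the effect of this one group at this position and no general trend. No evidence is available to account for the loss. On these data alone, whether a methyl, a shorter chain or the free amine at this carbon would retain more of the effect remains open.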